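The compounds below may be only part of what the source reports. "The series", "measured", "known", "first", "only" and "open" are said of these compounds alone.

Compound 2, `O=C(CBr)Nc1ccc(C(=O)/C=C/c2ccc(Cl)cc2)cc1`, is tested in a functional assay on the whole organism (strain albino) for inhibition, with Rattus norvegicus as the target, read by paw edema, with stated times of 30 min and 2 h, at a dose of 100 mg/kg by the oral route (on this read-out lower numbers stand for less inhibition and higher numbers for more inhibition at the one dose given (going by the name of the read-out)), where it gives 52%, the highest of the three numbers recorded. Compound 3, `COc1ccc(/C=C/C(=O)c2ccc(NC(=O)CBr)cc2)cc1`, gives 42%, and the change that sets it apart is a number 10 percentage points lower from compound 2 to compound 3 (within the scatter). Compound 1, `Nc1ccc(C(=O)/C=C/c2ccco2)cc1`, gives 38%, and it already carries the ring that enters below, though it lacks the bromoacetamide of compound 2. Compound 4, `O=C(CBr)Nc1ccc(C(=O)/C=C/c2ccco2)cc1`, differs from compound 2 in one place: furan-2-yl in place of 4-chlorophenyl on a double-bonded chain carbon bound to a double-bonded chain carbon. Going by the values given here, no recorded step measures this change directly, and the one recorded step lies within the scatter, so only a modest shift is expected. Compound 4 is estimated to give 44%, between 30% and 58%, a step of a number 8 percentage points lower from compound 2 to compound 4 (within the scatter) from compound 2.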

Compound 4, a percentage reported as inhibition, in the whole organism at one dose (the size of the read-out at that dose, not a potency): 37%
Compound 4: the middle estimate sits 7 percentage points above what was measured; low and high end bracket the measured number.
By their numbers in this assay, from the lowest: compounds 4, 1, 3 and 2 (each within the scatter of the next, the first and the last beyond it).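

In this assay, going by these compounds alone, the ring on this double-bonded chain carbon matters: with the bromoacetamide kept, furan-2-yl in place of 4-chlorophenyl gives a number 15 percentage points lower from compound 2 to compound 4 (beyond the scatter) and provides the first single-place step beyond the scatter. With furan-2-yl kept, adding (bromomethyl)carbonyl on the nitrogen gives a number 1 percentage points lower from compound 1 to compound 4 (within the scatter) and so shows no readable effect in this pair. No available measurement explains either step. Still open, going by these compounds, is how a plain phenyl or thiophen-2-yl ring would read here, and whether a free amine would match the bromoacetamide with 4-chlorophenyl in place.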